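This account rests on a few compounds, and the source may have more. Where it says the series, first, only, none or still open, it means among the compounds named here.

Values in a functional assay on PANC-1 cells (Homo sapiens) for inhibition, read by MTT assay, with a stated time of 72 h; a higher number here means a weaker inhibitor, a lower number a stronger inhibitor:
Compound 1 `O=C(Nc1cc(Cl)cc2cccnc12)c1cnccn1`: 2700 nM
Compound 2 `COc1cc(NC(=O)c2ncccn2)c2ncccc2c1`: 9000 nM
Compound 3 `NCCOc1cc(NC(=O)c2cnccn2)c2ncccc2c1`: > 10000 nM (a limit, not a number)

Compound 3 has no number of its own and stands only at a limit, > 10000 nM. Its place is the limit of > 10000 nM in this assay, at which 1 of the 3 values shown sits.

Compound 4 `NCCOc1cc(NC(=O)c2ncccn2)c2ncccc2c1` differs from compound 3 by pyrimidin-2-yl in place of pyrazin-2-yl on a carbonyl carbon.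

One measured step is available, an at least 3.7-fold higher number from compound 1 to compound 3 (0.56 log units; beyond the scatter). It lies beyond the scatter, but it is a different change, 2-aminoethoxy in place of chloro on an aromatic carbon, so it does not measure this exchange. Among the compounds with values here, no measured step tests pyrimidin-2-yl against pyrazin-2-yl, and no step beyond the scatter is therefore expected in this assay.

The estimated step is a step that the limit leaves unreadable from compound 3 to compound 4, and it is expected to stay within the scatter. A report of only a limit is the likeliest outcome. For compound 4 the estimate is 13000 nM, with an expected range from 6000 nM to 30000 nM.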

Compound 4, half-maximal inhibitory concentration: > 10000 nM
Compound 4: only a limit was reported; the forecaster's own chance of this, stated with the estimate: 70%; the middle value does not contradict the limit.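

In this assay compound 4 gives > 10000 nM, which is a limit and not a number. The exchange of pyrazin-2-yl for pyrimidin-2-yl on a carbonyl carbon therefore cannot be read, and the limit is now shared by more of the compounds: the limit of > 10000 nM in this assay, at which 2 of the 4 values shown sit. The one step that can be read is an at least 1.1-fold higher number from compound 2 to compound 4 (0.04 log units; that floor lies within the scatter), with aminomethyl in place of hydrogen on a saturated chain carbon bound to an oxygen on an aromatic ring, so this change is not shown to move the value beyond the scatter.

Going by these compounds, it remains open whether pyrimidin-2-yl and pyrazin-2-yl differ at all where both compounds of a pair give a number. Also open, on these data alone, is how a longer chain carrying the amine, or a carboxylic acid in place of the amine, would read in this assay.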